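The compounds below may be only part of what the source reports. "The series", "measured", "known", "first", "only" and "open" are said of these compounds alone.

Compound 1 `COc1nn(Cc2ccc(NC(C)=O)cc2)c(=O)o1` — 37%
Compound 2 `COc1nn(Cc2cccc(NC(=O)c3ccccc3)c2)c(=O)o1` — "not active" (no number reported)
Compound 3 `COc1nn(Cc2cccc(C#N)c2)c(=O)o1` — "not active" (no number reported)

These three compounds share one core and differ only in the group on the benzene ring. In an assay on COS-7 cells for inhibition of Fatty-acid amide hydrolase 1 (Homo sapiens), read by scintillation counting, with a stated time of 10 min, tested at 10 uM (a lower number here means less inhibition, a higher number more inhibition at the concentration tested (going by the name of the read-out)), compound 1 gives 37%, while compound 2 is recorded as "not active" (no number reported) and compound 3 as "not active" (no number reported). So compound 3 stands without a number, alongside compound 2 in that respect, and only compound 1 shows a measurable effect here.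

Compound 4 `COc1cccc(Cn2nc(OC)oc2=O)c1` is not yet measured. It differs from compound 3 by methoxy in place of cyano on an aromatic carbon. Within the data shown here, no step between measured compounds shows what this exchange does, so in this assay no shift beyond the usual scatter is expected. Compound 4 is estimated at 10%, within 0% to 30%.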

Compound 4, a percentage reported as inhibition, at one concentration (the size of the read-out at that concentration, not a potency): "not active" (no number reported)
Compound 4 has no reported number here, so the estimate cannot be set against anything.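

Compound 3 and compound 4 both lack a number, so no step can be read from exchanging cyano for methoxy. As far as these compounds go, how either group affects inhibition stays open. No available evidence bears on this result.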